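Methyl position on the aryl ether of compound 2

This account rests on a few compounds, and the source may have more. Where it says the series, first, only, none or still open, it means among the compounds named here.

For the measured compounds named here, compound 2 `Cc1cc(Cl)ccc1OCc1nc(N)nc(N2CCN(C)CC2)n1` gives 911 nM in an assay on HEK293 cells for displacement of a labelled ligand from 5-hydroxytryptamine receptor 6 (Homo sapiens), read by radioligand binding, with a stated time of 1 h (a higher number here means a weaker inhibitor, a lower number a stronger inhibitor), the highest of the two numbers measured so far; its nearest neighbour is compound 1 `CN1CCN(c2nc(N)nc(COc3ccccc3Cl)n2)CC1`, which in this assay gives 129 nM. Going by the values given here, the only measured step, a 7.1-fold higher number from compound 1 to compound 2 (0.85 log units; beyond the scatter), accompanied a change of the aryl group on the oxygen on a saturated carbon, 4-chloro-2-methylphenyl in place of 2-chlorophenyl.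

Compound 3 `Cc1cc(OCc2nc(N)nc(N3CCN(C)CC3)n2)ccc1Cl` has not been measured. It differs from compound 2 as 4-chloro-3-methylphenyl in place of 4-chloro-2-methylphenyl on an oxygen on a saturated carbon: the same atoms, joined differently, with the methyl placed as the two group names say while the chlorine remains. Among the compounds with values here, no measured step bears directly on a change of this kind; the one available step, a 7.1-fold higher number from compound 1 to compound 2 (0.85 log units; beyond the scatter), shows that altering the substitution pattern of this aryl group shifted the number modestly. Within the data shown here, with no direct precedent, the expectation for compound 3 is a step of a 1.5-fold lower number from compound 2 to compound 3 (0.18 log units; within the scatter), of uncertain direction and most likely not beyond the scatter. Compound 3 is therefore estimated at 600 nM, with a range of 200 nM to 2000 nM.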

Compound 3, inhibition constant: 355 nM
Estimate against measurement, compound 3: 1.7-fold (0.23 log units) above; the measured number falls inside the stated range.
By their numbers in this assay, from the lowest: compound 1; then compound 3; then compound 2.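

In this assay the placing of the methyl counts on its own: with the chlorine kept and the same heavy atoms, there is a 2.6-fold lower number from compound 2 to compound 3 (0.41 log units; beyond the scatter) with 4-chloro-3-methylphenyl in place of 4-chloro-2-methylphenyl. The earlier difference between compound 1 and compound 2 therefore cannot be read as a matter of which atoms the aryl group carries alone. The change recovers only part of that difference, as 4-chloro-3-methylphenyl in place of 2-chlorophenyl still leaves a 2.8-fold higher number from compound 1 to compound 3 (0.44 log units; beyond the scatter) and compound 1 remains the lowest of the three, with its steps to both others beyond the scatter. Nothing available explains why the methyl placement shifts the number.

Still open, from the compounds shown here alone, is how much of the remaining gap belongs to the methyl and how much to the chlorine, which a plain 4-chlorophenyl group on the same oxygen would help to separate. Also open, going by these compounds, is whether the methyl itself can be exchanged at this place, for example for a methoxy, a trifluoromethyl or a second chlorine, and whether any such group would bring the number down to that of compound 1 or past it.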